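Swapping the halogenated phenyl ring on compound 2

The source may report more compounds than this note shows. Statements on the series, on what has been measured and on what is new or still open speak of the compounds shown alone.

Compound 1, `Ic1ccc(Cn2cc(CCCOc3cccc4cccnc34)nn2)cc1`: > 250 ug/mL
Compound 2, `Fc1ccc(Cn2cc(CCCOc3cccc4cccnc34)nn2)cc1F`: 42.1 ug/mL

In a functional assay on NCI/ADR-RES cells (Homo sapiens) for inhibition, read by sulforhodamine B assay, with a stated time of 48 h (a lower number here means a stronger inhibitor of growth, a higher number a weaker inhibitor of growth), compound 1 gives > 250 ug/mL, which is a limit of the assay rather than a number. For the measured compounds named here, compound 2 gives 42.1 ug/mL in this assay, the only true number among the two values shown. The step of an at least 5.9-fold lower number from compound 1 to compound 2 (0.77 log units; beyond the scatter) shows that the halogen pattern on this ring matters, though one end of it is a limit (the limit of > 250 ug/mL in this assay, at which 1 of the 2 values shown sits). Compound 3, `Clc1cc(Cl)c(Cn2cc(CCCOc3cccc4cccnc34)nn2)c(Cl)c1`, differs from compound 2 by 2,4,6-trichlorophenyl in place of 3,4-difluorophenyl on a saturated chain carbon bound to an aromatic nitrogen. Going by the values given here, only that one step bears on this change, and it rests on a limit, so the direction is uncertain. The expected step is a 1.9-fold higher number from compound 2 to compound 3 (0.28 log units; within the scatter). Compound 3 is estimated at 80 ug/mL, with a range from 20 ug/mL to 250 ug/mL.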

Compound 3, concentration for 50% growth inhibition: 2.8 ug/mL
Beside the measured number, compound 3's estimate is 29-fold (1.46 log units) above it; measured number below the stated range.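

The ring on a saturated chain carbon bound to an aromatic nitrogen can do much more for growth inhibition than the first pair showed: in this assay, 2,4,6-trichlorophenyl in place of 3,4-difluorophenyl gives a 15-fold lower number from compound 2 to compound 3 (1.18 log units; beyond the scatter). Against 4-iodophenyl, the same group gives an at least 89-fold lower number from compound 1 to compound 3 (1.95 log units; beyond the scatter). The value of compound 1 is a limit, not a true number, so that step has no fixed size: the limit of > 250 ug/mL in this assay, at which 1 of the 3 values shown sits.

Compound 2 and compound 3 differ in both halogen and substitution pattern, so the effects of the two cannot be separated. Going by these compounds, how a ring carrying an amine or a carboxylic acid would behave also remains open.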